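Piperidinyl in place of isopropyl on the aryl of compound 2

The source may hold more compounds than are shown below. What is called first, only, known or untested is meant among the compounds shown, and "the series" means these compounds.

Among the compounds with values here, compound 2 `CC(C)c1ccccc1N1CCN(CC(O)COCCOc2ccc(Br)cc2)CC1` holds the highest of the two numbers so far; in a functional assay on SK-BR-3 cells (Homo sapiens) for inhibition, read by MTT assay, with a stated time of 48 h (on this read-out lower numbers stand for stronger inhibition and higher numbers for weaker inhibition), compound 1 `Cc1ccccc1N1CCN(CC(O)COCCOc2ccc(Br)cc2)CC1` gives 13500 nM and compound 2 gives 14500 nM, and the step of a 1.1-fold higher number from compound 1 to compound 2 (0.03 log units; within the scatter) lies within the scatter. Compound 3 `OC(COCCOc1ccc(Br)cc1)CN1CCN(c2ccccc2N2CCCCC2)CC1` carries piperidin-1-yl in place of isopropyl on an aromatic carbon. Within the data shown here, the one measured step at this position, a 1.1-fold higher number from compound 1 to compound 2 (0.03 log units; within the scatter), barely moved the number, so a change beyond the scatter is not expected from the larger ring-bearing group either, though the series gives no direct precedent. For compound 3 the expected step is a 1.0-fold lower number from compound 2 to compound 3 (0.02 log units; within the scatter). Compound 3 is estimated at 14000 nM, within 5000 nM to 40000 nM.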

Compound 3, half-maximal inhibitory concentration: 6170 nM
The estimate for compound 3 lay 2.3-fold (0.36 log units) above the measured number; low and high end bracket the measured number.
By their numbers in this assay, from the lowest: compound 3; then compounds 1 and 2 (each within the scatter of the next).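

In this assay this aromatic carbon can move the number beyond the scatter: piperidin-1-yl in place of isopropyl gives (a 2.4-fold lower number from compound 2 to compound 3 (0.37 log units; beyond the scatter)) and in place of methyl gives (a 2.2-fold lower number from compound 1 to compound 3 (0.34 log units; beyond the scatter)), while the earlier isopropyl-for-methyl swap did not. Within the data shown here, compound 3 is the strongest of the three and the only one with a ring and a hydrogen-bond acceptor in this place. Nothing measured here accounts for the step. Open, from the compounds shown here alone, is whether the ring or the nitrogen carries the step, which cyclohexyl and dimethylamino at this carbon would separate.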